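The source may report more compounds than this note shows. Statements on the series, on what has been measured and on what is new or still open speak of the compounds shown alone.

Measured compounds:
Compound 1, `COc1ccc(C(=O)/C=C/c2ccc(F)cc2)c2c1C=CC(C)(C)O2`, in a functional assay on HT-29 cells (Homo sapiens) for antiproliferative activity, read by MTT assay, with a stated time of 24 h (a lower number here means a stronger inhibitor, a higher number a weaker inhibitor), gives > 10000 nM, which is a limit of the assay and not a number.
Compound 2, `COc1ccc(C(=O)/C=C/c2cccc(F)c2)c2c1C=CC(C)(C)O2`, in this assay gives > 10000 nM, again a limit of the assay.

Among the compounds with values here, the only step between measured compounds, a step that the two limits leave unreadable from compound 1 to compound 2, therefore cannot be read in size or direction. Within the data shown here, compound 2 thus stands at the limit of this assay, and the one further value shown is also a limit: the limit of > 10000 nM in this assay, at which 2 of the 2 values shown sit.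

Compound 3, `COc1ccc(C(=O)/C=C/c2ccc(Br)cc2)c2c1C=CC(C)(C)O2`, differs from compound 2 in one place: 4-bromophenyl in place of 3-fluorophenyl on a double-bonded chain carbon bound to a double-bonded chain carbon. Among the measured compounds shown here, no measured step bears directly on this change. The halogen returns to the ring placement seen in compound 1, and fluorine gives way to bromine, a change on which the two measured compounds say nothing beyond their shared limit. With both neighbours sitting at the limit, compound 3 is expected to give a value at or near the same limit, the expected step that the limit leaves unreadable from compound 2 to compound 3 being no more than the scatter allows. Compound 3 is therefore estimated at 15000 nM, with a range from 3000 nM to 60000 nM.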

Compound 3, half-maximal inhibitory concentration: > 10000 nM
Compound 3: a limit, no number; the forecaster's own chance of this, stated with the estimate: 70%; the middle value lies beyond the limit too.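

In this assay compound 3 gives > 10000 nM as a limit of the assay and not a number. Within the data shown here, no step from compound 1 or compound 2 to compound 3 can therefore be read, in size or in direction: the limit of > 10000 nM in this assay, at which 3 of the 3 values shown sit. The compounds shown leave open how far apart compound 1, compound 2 and compound 3 lie in this assay and whether the halogen or its ring placement matters there at all.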